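This account rests on a few compounds, and the source may have more. Where it says the series, first, only, none or still open, it means among the compounds named here.

Measured so far:
compound 1 `CC1=NN(c2ccccc2)C(=O)[C@]12C(=O)C=CC[C@H]2c1ccc(C)cc1` gives 5720 nM;
compound 2 `CC1=NN(c2ccccc2)C(=O)[C@]12C(=O)C=CC[C@@H]2c1cccc(C)c1` gives 8000 nM;
compound 3 `CC1=NN(c2ccccc2)C(=O)[C@]12C(=O)C=CC[C@@H]2c1ccccc1` gives 9080 nM.

All three were tested in a functional assay on MDA-MB-231 cells (Homo sapiens) for inhibition, read by MTT assay, with a stated time of 72 h; a lower number here means a stronger inhibitor, a higher number a weaker inhibitor. Compounds 3 and 2 differ by methyl in place of hydrogen on an aromatic carbon, and that change made a 1.1-fold lower number from compound 3 to compound 2 (0.05 log units; within the scatter). Compound 1 stands nearest to compound 2 and furthest from compound 3, yet both gaps are within the scatter, so no order among the three can be drawn. How the core of compound 1 differs from that of compound 3 is not broken down here.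

Compound 4 `CC1=NN(c2ccc(C)cc2)C(=O)[C@]12C(=O)C=CC[C@H]2c1ccc(C)cc1` is not yet measured. It differs from compound 1 by methyl in place of hydrogen on an aromatic carbon. Within the data shown here, this is the same kind of change as the one from compound 3 to compound 2, but not the same: in that pair the methyl sits meta to a large group, whereas in compound 4 it sits para to a large group. The expected step is a 1.1-fold lower number from compound 1 to compound 4 (0.06 log units; within the scatter), and this expectation rests on the like change having given a 1.1-fold lower number from compound 3 to compound 2 (0.05 log units; within the scatter). Compound 4 is therefore estimated at 5000 nM, between 2500 nM and 10000 nM.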

Compound 4, half-maximal inhibitory concentration: 8280 nM
Compound 4: middle estimate off by 1.7-fold (0.22 log units), on the low side; measured number inside the range.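

In this assay, methyl in place of hydrogen on an aromatic carbon, here phenyl to 4-methylphenyl, gave a 1.4-fold higher number from compound 1 to compound 4 (0.16 log units; within the scatter). Set beside the earlier step, the change shows no gap between the two cores that can be told from the usual scatter: the same change on two cores in this assay, a 1.1-fold lower number (0.05 log units; within the scatter) from compound 3 to compound 2 and a 1.4-fold higher number (0.16 log units; within the scatter) from compound 1 to compound 4, 1.6-fold (0.22 log units) apart, within the scatter of two such steps. Among these compounds, this shows that on neither core did the methyl produce a readable step, but it does not show that the change is without effect throughout the series or that the two steps are truly equal; only two pairs stand here, and the methyl sits at a different place in each.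

The compounds shown carry only hydrogen or methyl at these aromatic places, so what a methoxy group, a chlorine or an amine would do there stays open. They also leave open what a methyl would do on the core of compound 3 at the place it holds in compound 4.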